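Third aryl group on the shared core

The compounds below may be only part of what the source reports. "The series", "measured", "known", "first", "only" and "open" are said of these compounds alone.

Measured in a functional assay on HeLa cells (Homo sapiens) for antiproliferative activity, read by spectrophotometry, with a stated time of 2 days; on this read-out lower numbers stand for stronger inhibition of growth and higher numbers for weaker inhibition of growth:
compound 1 `Cc1ccc(Nc2ncc(C(F)(F)F)c(N3Cc4cccc(N(C)S(C)(=O)=O)c4C3)n2)c(Cl)c1` gives 10900 nM
compound 2 `CN(c1cccc2c1CN(c1nc(Nc3ccc(C(F)(F)F)cc3)ncc1C(F)(F)F)C2)S(C)(=O)=O` gives > 30000 nM (a limit)

Compound 2 stands at the limit of > 30000 nM in this assay, at which 1 of the 2 values shown sits, so only a limit is known for it. Compound 3 `Cc1cc(C)cc(Nc2ncc(C(F)(F)F)c(N3Cc4cccc(N(C)S(C)(=O)=O)c4C3)n2)c1` differs from it as follows: 3,5-dimethylphenyl in place of 4-(trifluoromethyl)phenyl on a nitrogen on an aromatic ring. Going by the values given here, one measured step bears on this place, an at least 2.7-fold higher number from compound 1 to compound 2 (0.43 log units; beyond the scatter). Among the compounds with values here, it is a single step, and compound 1 at 10900 nM is the only measured compound without the 4-(trifluoromethyl)phenyl group. A modest step to a lower number in this assay is therefore expected, with a return to the limit still possible. The estimated step is an at least 2.1-fold lower number from compound 2 to compound 3 (0.33 log units; beyond the scatter). Compound 3 is expected at 14000 nM, within 5000 nM to 30000 nM.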

Compound 3, concentration for 50% growth inhibition: > 30000 nM
Compound 3: only a limit was reported (the forecaster's own chance of this, stated with the estimate: 30%); at least 2.1-fold (0.33 log units) between middle value and limit.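

In this assay compound 3 gives > 30000 nM, which is a limit. Going by these compounds alone, with 3,5-dimethylphenyl in place of 2-chloro-4-methylphenyl there is an at least 2.7-fold higher number from compound 1 to compound 3 (0.43 log units; beyond the scatter), so compound 1 remains the only compound here with a number rather than a limit, and the step between compound 2 and compound 3 cannot be read. A second aryl group without the chlorine of compound 1 now ends at the same limit: the limit of > 30000 nM in this assay, at which 2 of the 3 values shown sit.

From the compounds shown here alone, it remains open whether the chlorine or the methyl of compound 1 accounts for its measurable value. Also open, going by these compounds, is how an amine or a carboxylic acid on this aryl group would read.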